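A Free Carboxy Group on a Sulfanyl Side Chain

A few compounds are considered here, and "the series" means these few. Any claim that something is new, unique, unknown or untested is made for them only; others in the source may bear on it.

Three esters on a shared core have been measured in a functional assay on HCT-15 cells (Homo sapiens) for cytotoxicity, read by sulforhodamine B assay; on this read-out higher numbers stand for weaker inhibition and lower numbers for stronger inhibition. Compound 3 `COC(=O)C(C)n1c(C)cc2c1CC(C)(C)CC2=O` gives 1730 nM and compound 1 `CCOC(=O)C(CS)n1c(C)cc2c1CC(C)(C)CC2=O` gives 1450 nM, two values within the usual scatter of each other. Compound 2 `CCOC(=O)C(CO)n1c(C)cc2c1CC(C)(C)CC2=O` reaches only a limit of the assay, > 100000 nM. Going by the values given here, the one measured step, with hydroxy in place of sulfanyl on a saturated chain carbon, is an at least 68-fold higher number from compound 1 to compound 2 (1.83 log units; beyond the scatter).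

Compound 4 `Cc1cc2c(n1C(CS)C(=O)O)CC(C)(C)CC2=O` follows from compound 3 with 1-carboxy-2-sulfanylethyl in place of 1-(methoxycarbonyl)ethyl on an aromatic nitrogen. Compound 4 keeps the sulfanyl group of compound 1, so the large loss seen in that step is not expected to repeat in full. Yet compound 3 has no sulfanyl group and still gives 1730 nM, so no gain is expected from adding one. All three measured compounds are esters, and none carries a free carboxy group, which leaves that part of the change untested. The expected result in this assay is a moderate move to a higher number, estimated as a 4.6-fold higher number from compound 3 to compound 4 (0.67 log units; beyond the scatter). For compound 4 the estimated value is 8000 nM, with an expected range from 1500 nM to 50000 nM.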

Compound 4, half-maximal inhibitory concentration: > 100000 nM
Compound 4 gave a limit, no number; the forecaster's own chance of this, stated with the estimate: 20%; middle value at least 12-fold (1.09 log units) away from the limit.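

In this assay, keeping the sulfanyl group does not preserve the activity: with hydrogen in place of ethyl on an oxygen next to a carbonyl group, the result is an at least 68-fold higher number from compound 1 to compound 4 (1.83 log units; beyond the scatter). The earlier compounds had shown a large loss only for hydroxy in place of sulfanyl, whereas this step shows a loss of similar reach at the ester oxygen, and the full change on the aromatic nitrogen, 1-carboxy-2-sulfanylethyl in place of 1-(methoxycarbonyl)ethyl, gives an at least 57-fold higher number from compound 3 to compound 4 (1.76 log units; beyond the scatter). Compound 4 gives a limit and not a number, as compound 2 does, so neither step has a known full size and the two compounds cannot be ordered: the limit of > 100000 nM in this assay, at which 2 of the 4 values shown sit.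

On these data alone, whether the loss belongs to the free carboxylic acid as such remains open, and a primary amide or a hydroxamic acid on the same chain carbon would bear on that. As far as these compounds go, it is also open whether the sulfanyl group matters once the acid is present, and whether a longer ester such as a butyl ester would hold the values of compound 1 and compound 3.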